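The source may hold more compounds than are shown below. What is called first, only, known or untested is meant among the compounds shown, and "the series" means these compounds.

Measured so far, in an assay on isolated protein (Oryctolagus cuniculus) with Thromboxane-A synthase (Homo sapiens) as the target, tested at 1 uM; on this read-out higher numbers stand for more inhibition at the one concentration tested (going by the name of the read-out) and lower numbers for less inhibition:
- compound 1, `CCCn1nc(-c2cccnc2)c2ccccc2c1=O`, gives 86%
- compound 2, `CCCCn1nc(-c2cccnc2)c2ccccc2c1=O`, gives 91%
- compound 3, `O=c1c2ccccc2c(-c2cccnc2)nn1C1CCCC1`, gives 97%

Compound 3 holds the highest of these three numbers. Its step from compound 2 is within the scatter, a number 6 percentage points higher from compound 2 to compound 3 (within the scatter), so the two cannot be ordered with confidence; only its step from compound 1 is beyond the scatter, a number 11 percentage points higher from compound 1 to compound 3 (beyond the scatter), a modest rise.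

Compound 4, `CC(=O)OCCn1nc(-c2cccnc2)c2ccccc2c1=O`, is not yet measured. The change from compound 3 is 2-acetoxyethyl in place of cyclopentyl on an aromatic nitrogen. The two steps that bear on it are those that also swap the group on the same aromatic nitrogen: the step of a number 11 percentage points higher from compound 1 to compound 3 (beyond the scatter) and the step of a number 6 percentage points higher from compound 2 to compound 3 (within the scatter). Both are small, and both run toward compound 3. Within the data shown here, the new group differs more strongly from cyclopentyl than propyl or butyl do, and no measured step shows what an acetoxyethyl group on this nitrogen does, so the expectation rests on loose ground. Compound 4 is expected to sit somewhat lower than compound 3, with an estimated step of a number 17 percentage points lower from compound 3 to compound 4 (beyond the scatter) in this assay. Compound 4 is therefore estimated at 80%, within a range of 60% to 93%.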

Compound 4, a percentage reported as inhibition, at one concentration (the size of the read-out at that concentration, not a potency): 32%
For compound 4 the middle estimate is 48 percentage points above the measured one; measured number outside the range, below it.
By their numbers in this assay, from the lowest: compound 4; then compounds 1, 2 and 3 (each within the scatter of the next, the first and the last beyond it).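

Among these compounds, the aromatic nitrogen had so far looked forgiving, since its three all-carbon groups all gave high numbers, but this result shows that the position does not accept every group in this assay: 2-acetoxyethyl in place of cyclopentyl brings a large fall (a number 65 percentage points lower from compound 3 to compound 4 (beyond the scatter)). The fall is also large against the two open chains, where acetoxy replaces ethyl (a number 59 percentage points lower from compound 2 to compound 4 (beyond the scatter)) or methyl (a number 54 percentage points lower from compound 1 to compound 4 (beyond the scatter)) on a saturated chain carbon two bonds along the chain from the aromatic nitrogen, so the loss does not depend on comparing with the ring of cyclopentyl alone. No measurement here explains why the acetoxy group has this effect.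

From the compounds shown here alone, what stays open is which feature of the acetoxy group goes with the loss: its oxygens, its carbonyl or simply its length. A 2-hydroxyethyl or 2-methoxyethyl group on this nitrogen, set beside an all-carbon hexyl chain, would begin to separate these possibilities.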